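A Ring Swap on the Ketone Side of the Chain

The source may hold more compounds than are shown below. What is called first, only, known or untested is meant among the compounds shown, and "the series" means these compounds.

Of the compounds shown here, two have been tested in a functional assay on MCF7 cells (Homo sapiens) for inhibition, read by MTT assay, with a stated time of 48 h; a lower number here means a stronger inhibitor, a higher number a weaker inhibitor. Compound 1 `COc1ccc(-c2cc(/C=C/C(=O)c3ccc(N)cc3)[nH]n2)cc1` gives 800 nM in this assay. Compound 2 `COc1cc(-c2cc(/C=C/C(=O)c3ccc(Cl)c(Cl)c3)[nH]n2)cc(OC)c1OC` gives 3200 nM in this assay, the higher of the two numbers, with compound 1 sitting apart from it beyond the usual scatter. Compound 3 `COc1ccc(C(=O)/C=C/c2cc(-c3cc(OC)c(OC)c(OC)c3)n[nH]2)cc1F` is not yet measured; it differs from compound 2 in one place: 3-fluoro-4-methoxyphenyl in place of 3,4-dichlorophenyl on a carbonyl carbon. For the measured compounds named here, no measured pair shows this exact change. Compound 3 is expected to come in at 1500 nM, within 500 nM to 5000 nM. This expected step from compound 2 to compound 3 of a 2.1-fold lower number from compound 2 to compound 3 (0.33 log units; beyond the scatter) is a modest move toward a lower number, close to the scatter.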

Compound 3, half-maximal inhibitory concentration: 3000 nM
For compound 3 the middle estimate is 2.0-fold (0.30 log units) below the measured one; low and high end bracket the measured number.
By their numbers in this assay, from the lowest: compound 1; then compounds 3 and 2 (each within the scatter of the next).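

In this assay, the exchange of 3,4-dichlorophenyl for 3-fluoro-4-methoxyphenyl on the carbonyl carbon gives a 1.1-fold lower number from compound 2 to compound 3 (0.03 log units; within the scatter) and so leaves no readable difference. At this position, then, the entering ring brings one hydrogen-bond acceptor and one more heavy atom, yet the two compounds cannot be told apart in this measurement. No measured evidence here accounts for this result. Still open, on these data alone, is how a carboxylic acid or a morpholine on this ring would read. Compound 1 differs from compound 2 in more than one place, so the source of its separate value also remains unresolved.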